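Swapping a thiophene amide for a sorbyl amide in threonine octylamides

This account rests on a few compounds, and the source may have more. Where it says the series, first, only, none or still open, it means among the compounds named here.

Measured compounds:
compound 1 `CCCCCCCCCCCCCCCCCCNC(=O)[C@@H](N)[C@@H](C)O` — 21300 nM
compound 2 `CCCCCCCCNC(=O)[C@@H](NC(=O)c1ccco1)[C@@H](C)O` — 64500 nM
compound 3 `CCCCCCCCNC(=O)[C@@H](NC(=O)c1cccs1)[C@@H](C)O` — 32200 nM

In a functional assay on A-431 cells (Homo sapiens) for cytotoxicity, read by MTT assay, with a stated time of 48 h (a lower number here means a stronger inhibitor, a higher number a weaker inhibitor), compound 3 gives 32200 nM, the second highest of the three numbers, with compound 1 closest and compound 2 furthest, both within the scatter. Compound 4 `C/C=C/C=C/C(=O)N[C@H](C(=O)NCCCCCCCC)[C@@H](C)O` differs from compound 3 in one place: penta-1,3-dien-1-yl in place of thiophen-2-yl on a carbonyl carbon. Among the measured compounds shown here, the only measured step at this position is a 2.0-fold lower number from compound 2 to compound 3 (0.30 log units; within the scatter), which stayed within the scatter, and no measured compound carries an open chain on this carbonyl carbon. Compound 4 is therefore expected to show little change beyond the scatter, with a 1.1-fold lower number from compound 3 to compound 4 (0.03 log units; within the scatter) as the estimated step. The estimate for compound 4 is 30000 nM, expected to lie between 10000 nM and 90000 nM.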

Compound 4, half-maximal inhibitory concentration: 58200 nM
Beside the measured number, compound 4's estimate is 1.9-fold (0.29 log units) below it; the range from low to high includes it.
By their numbers in this assay, from the lowest: compounds 1, 3, 4 and 2 (each within the scatter of the next, the first and the last beyond it).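

In this assay, among the compounds shown here, the open penta-1,3-dien-1-yl chain is the first group on this carbonyl carbon without a ring, and it gives a 1.8-fold higher number from compound 3 to compound 4 (0.26 log units; within the scatter) and a 1.1-fold lower number from compound 2 to compound 4 (0.04 log units; within the scatter). An aromatic ring at this position is therefore not needed for a number of this size, as furan-2-yl, thiophen-2-yl and penta-1,3-dien-1-yl all stay within the scatter of each other. No measured evidence bears on why this is so. The compounds shown leave open whether a saturated pentyl chain, a phenyl ring or a carboxylic acid on this carbonyl carbon would move the number beyond the scatter.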